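Swapping phenyl for pyridin-2-yl on a shared core

A few compounds are considered here, and "the series" means these few. Any claim that something is new, unique, unknown or untested is made for them only; others in the source may bear on it.

Four compounds share one core and differ in the aromatic groups attached to it. In a functional assay on HCT-15 cells (Homo sapiens) for cytotoxicity, read by CCK-8 assay and cell counting, with a stated time of 2 days (a lower number here means a stronger inhibitor, a higher number a weaker inhibitor), compound 1 `Oc1ccc(-c2cc(-c3ccccn3)nc(-c3ccccc3Cl)c2)cc1` has "not determined" (no result reported), so no number is available for it. Compound 2 `Oc1ccc(-c2cc(-c3cccc(Cl)c3)nc(-c3ccccn3)c2)cc1` gives 28200 nM in this assay. Within the data shown here, compound 3 `Oc1ccc(-c2cc(-c3ccccc3)nc(-c3ccc(Cl)cc3)c2)cc1` gives 6920 nM in this assay, the lowest of the two numbers so far, and its gap to compound 2 lies beyond the usual scatter of repeated measurements.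

Compound 4 `Oc1ccc(-c2cc(-c3ccc(Cl)cc3)nc(-c3ccccn3)c2)cc1` is the next compound to be measured in this assay. Compared with compound 3, the change is pyridin-2-yl in place of phenyl on an aromatic carbon. Among the measured compounds shown here, no measured pair shows this exact change on its own, so the size of the step is uncertain. The expectation leans toward a higher number because compound 2 gives 28200 nM, though the gap between compound 2 and compound 3 also involves a different chlorophenyl group. The expected step of a 1.9-fold higher number from compound 3 to compound 4 (0.27 log units; within the scatter) is modest, near the edge of the scatter. Compound 4 is expected to give 13000 nM, within a range from 4500 nM to 40000 nM.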

Compound 4, half-maximal inhibitory concentration: 21300 nM
For compound 4 the middle estimate is 1.6-fold (0.21 log units) below the measured one, within the range that was stated.
By their numbers in this assay, from the lowest: compound 3; then compounds 4 and 2 (each within the scatter of the next).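

In this assay, among these compounds, the step of a 3.1-fold higher number from compound 3 to compound 4 (0.49 log units; beyond the scatter) is the first reading of a single change at this position: with the 4-chlorophenyl group kept, pyridin-2-yl in place of phenyl gives a weaker result, and the change lies beyond the scatter. The other pair keeps pyridin-2-yl and swaps 3-chlorophenyl for 4-chlorophenyl; the step of a 1.3-fold lower number from compound 2 to compound 4 (0.12 log units; within the scatter) lies within the scatter, so these two chlorophenyl groups cannot be told apart here. Nothing measured here bears on the reason for either step.

Going by these compounds, it remains open whether the weaker result is specific to pyridin-2-yl or would also appear with another group at this position, such as an amine or a carboxylic acid. On these data alone, whether the 4-hydroxyphenyl group contributes to the effect in these cells also remains open.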